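A few compounds are considered here, and "the series" means these few. Any claim that something is new, unique, unknown or untested is made for them only; others in the source may bear on it.

Measured so far:
compound 1, `C=CC(=O)Nc1cccc(Nc2nc(N/N=C(\C)c3ccc(OC)cc3)ncc2Cl)c1` — 4560 nM
compound 2, `C/C(=N\Nc1ncc(Cl)c(Nc2cccc(NC(=O)/C=C/CN(C)C)c2)n1)c1ccc(F)cc1` — 10200 nM

In an ADME assay on HT-29 cells (Homo sapiens) for inhibition, read by MTT assay, with a stated time of 72 h (on this read-out lower numbers stand for stronger inhibition and higher numbers for weaker inhibition), compound 1 gives 4560 nM. Compound 2 gives 10200 nM in this assay, the higher of the two numbers, and its gap to compound 1 lies beyond the usual scatter of repeated measurements.

Compound 3, `COc1ccc(/C(C)=N/Nc2ncc(Cl)c(Nc3cccc(NC(=O)/C=C/CN(C)C)c3)n2)cc1`, has not yet been measured. It differs from compound 2 in a single place: methoxy in place of fluoro on an aromatic carbon. Among the compounds with values here, no measured pair shows this change on its own, so the size of the step can only be guessed. The step from compound 2 to compound 3 in this assay is expected to be small, at most a little toward a lower number, and may well stay within the scatter: a 1.5-fold lower number from compound 2 to compound 3 (0.16 log units; within the scatter). Compound 3 is therefore estimated to give 7000 nM, with a plausible range from 2500 nM to 16000 nM.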

Compound 3, half-maximal inhibitory concentration: 6830 nM
Compound 3: middle estimate off by 1.0-fold (0.01 log units), on the high side, within the range that was stated.
By their numbers in this assay, from the lowest: compounds 1, 3 and 2 (each within the scatter of the next, the first and the last beyond it).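

In this assay, within the data shown here, the 4-fluorophenyl to 4-methoxyphenyl change gives a 1.5-fold lower number from compound 2 to compound 3 (0.17 log units; within the scatter) and so stays within the usual scatter; this is the first view of this change on its own, and at this place on the aromatic ring the two groups cannot be told apart. Among these compounds, compound 3 also gives the first clean look at the group on the carbonyl carbon, where 3-(dimethylamino)prop-1-en-1-yl in place of vinyl gives a 1.5-fold higher number from compound 1 to compound 3 (0.18 log units; within the scatter) and likewise stays within the scatter. Nothing available explains either result.

The compounds shown leave open how an amine or a carboxylic acid would behave on this aromatic carbon. They also leave open whether a longer chain on the carbonyl carbon, or a morpholine at its end, would give a step beyond the scatter.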